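Isobutyl in place of chloro: a permeability estimate

The compounds below may be only part of what the source reports. "The series", "measured", "known", "first", "only" and "open" are said of these compounds alone.

In a physicochemical assay for permeability, using PAMPA (a lower number here means that the compound crosses the layer more slowly, a higher number that the compound crosses the layer faster), compound 1 `C[C@@H](Oc1cc2oc(=O)n(CCC(=O)O)c2cc1Cl)c1ccc(F)cn1` gives 31 nm/s, compound 2 `O=C(O)CCn1c(=O)oc2cc(OCC3CCC3)c(Cl)cc21` gives 12 nm/s and compound 3 `O=C(O)CCn1c(=O)oc2cc(Cl)c(Cl)cc21` gives 24 nm/s. Compound 3 therefore stands within the scatter of both other compounds. Compound 4 `CC(C)Cc1cc2oc(=O)n(CCC(=O)O)c2cc1Cl` differs from it by isobutyl in place of chloro on an aromatic carbon. Among the compounds with values here, one measured step bears on this carbon: a 2.0-fold higher number from compound 2 to compound 3 (0.30 log units; within the scatter), with chloro in place of cyclobutylmethoxy, and it stays within the scatter. On that single step, no change beyond the scatter is expected in this assay, and the expected step is a 1.1-fold lower number from compound 3 to compound 4 (0.04 log units; within the scatter). Compound 4 is estimated at 22 nm/s, with an expected range of 10 nm/s to 50 nm/s.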

Compound 4, apparent permeability: < 10 nm/s
Compound 4 ended at the assay's limit; the forecaster's own chance of this, stated with the estimate: 3%; middle value at least 2.2-fold (0.34 log units) from the limit.
By their numbers in this assay, from the lowest: compounds 2, 3 and 1 (each within the scatter of the next, the first and the last beyond it). At a limit, below all of these: compound 4.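

In this assay, the group on this carbon now moves the number beyond the scatter: isobutyl in place of chloro gives an at least 2.4-fold lower number from compound 3 to compound 4 (0.38 log units; beyond the scatter), while the earlier step at this carbon stayed within it. Isobutyl in place of cyclobutylmethoxy gives an at least 1.2-fold lower number from compound 2 to compound 4 (0.07 log units; that floor lies within the scatter). Compound 4 stands at a limit of the assay, not at a number: the limit of < 10 nm/s in this assay, at which 1 of the 4 values shown sits.

Going by these compounds, how far compound 4 lies past that limit stays open. So does how an amine, a carboxylic acid or a longer chain on this carbon would compare with chloro.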